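Exchanging the Proline Amide for Azepane on the Piperidine

This account rests on a few compounds, and the source may have more. Where it says the series, first, only, none or still open, it means among the compounds named here.

The series centres on the shared core carried by compound 1 `Cc1nn([C@H](C)c2ccc(Cl)cc2Cl)c2nc(N3CC[C@H](N4CCC[C@H]4C(N)=O)[C@H](C)C3)cnc12`, whose saturated six-membered ring bears a 2-carbamoylpyrrolidin-1-yl group. In a functional assay on cells for antagonist activity at C-C chemokine receptor type 4 (Homo sapiens), read by fluorescence and calcium flux, with stated times of 2.5 s and 45 s (on this read-out higher numbers stand for weaker inhibition and lower numbers for stronger inhibition), compound 1 gives 170 nM, the second highest of the three numbers at hand. Compound 3 `CC1CN(c2cnc3cnn(C(C)c4ccc(Cl)cc4Cl)c3n2)CCC1N1CCCCC1`, which carries a piperidinyl group in the corresponding position on a core lacking the methyl, gives 238 nM in this assay, a value that sits within the scatter of compound 1. Compound 2 `C[C@@H]1CC(c2cnc3c(C#N)nn([C@H](C)c4ccc(Cl)cc4Cl)c3n2)=CC[C@@H]1N1CCC[C@H]1C(N)=O`, built on a cyclohexene with a nitrile on its core, gives 54 nM in this assay, and that number lies beyond the scatter from compound 1.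

Compound 4 `Cc1nn([C@H](C)c2ccc(Cl)cc2Cl)c2nc(N3CC[C@H](N4CCCCCC4)[C@H](C)C3)cnc12` is the one not yet measured. It differs from compound 1 in a single place: azepan-1-yl in place of 2-carbamoylpyrrolidin-1-yl on a saturated ring carbon. Among the compounds with values here, no step between two measured compounds isolates this change, so any expectation rests on what compound 1 and compound 3 show; their two values suggest that loss of the carboxamide need not move the number far. Compound 4 is therefore expected to give a value close to compound 1, with the step of a 1.5-fold higher number from compound 1 to compound 4 (0.18 log units; within the scatter) judged to lie within or only a little beyond the scatter, towards a weaker result. The estimate for compound 4 in this assay is 260 nM, with a range from 100 nM to 700 nM.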

Compound 4, half-maximal inhibitory concentration: 23 nM
The estimate for compound 4 lay 11-fold (1.05 log units) above the measured number; measured number outside the range, below it.
By their numbers in this assay, from the lowest: compound 4; then compound 2; then compounds 1 and 3 (each within the scatter of the next).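

In this assay, azepan-1-yl in place of 2-carbamoylpyrrolidin-1-yl gives a 7.4-fold lower number from compound 1 to compound 4 (0.87 log units; beyond the scatter), a step beyond the scatter and the only step shown that isolates this position. It shows that, on the core of compound 1, this saturated ring carbon next to the ring atom that bears a methyl group does not need the carboxamide, its hydrogen-bond donor or the defined stereocentre of the group that leaves: a seven-membered ring without them gives the lower number. Nothing at hand offers an explanation for the size of this step.

The compounds shown leave open whether the seven-membered ring itself matters, as unsubstituted pyrrolidin-1-yl and piperidin-1-yl groups do not appear here on the core of compound 1, and neither does an azepane carrying a hydroxyl group or a primary amine. Also open, going by these compounds, is whether the same exchange would give a step of similar size on the core of compound 2, which carries a nitrile and a cyclohexene.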